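Methoxy in Place of Hydrogen: An Expected Step

A few compounds are considered here, and "the series" means these few. Any claim that something is new, unique, unknown or untested is made for them only; others in the source may bear on it.

Of the compounds shown here, two have so far been measured in a functional assay for inhibition of cytochrome P450 11B1, mitochondrial (Bos taurus); a lower number here means a stronger inhibitor, a higher number a weaker inhibitor. Compound 1 `CC(C)(c1cccnc1)C(O)c1cccnc1` carries a hydroxy group on a saturated chain carbon bound to an aromatic carbon and a saturated chain carbon, and in this assay compound 1 gives 7050 nM. Compound 2 `CC(C)(Cc1cccnc1)c1cccnc1` has a hydrogen at that carbon instead, and in this assay compound 2 gives 2640 nM. The step of a 2.7-fold lower number from compound 1 to compound 2 (0.43 log units; beyond the scatter) shows that trading the hydroxy group for hydrogen made the inhibitor stronger by a modest amount. Among the two numbers known, compound 2 stands at the lowest, with compound 1 as its only neighbour.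

Compound 3 `COC(c1cccnc1)C(C)(C)c1cccnc1` has not yet been measured. It differs from compound 2 by methoxy in place of hydrogen on a saturated chain carbon bound to an aromatic carbon and a saturated chain carbon. Going by the values given here, the one comparison that bears on this change is the step of a 2.7-fold lower number from compound 1 to compound 2 (0.43 log units; beyond the scatter), which points to a weaker inhibitor when an oxygen-bearing group sits at this carbon rather than hydrogen. A modest rise toward a higher number is therefore expected for compound 3, giving an estimate of 4500 nM within 1500 nM to 14000 nM. This corresponds to an estimated step of a 1.7-fold higher number from compound 2 to compound 3 (0.23 log units; within the scatter), expected to sit close to the edge of the scatter.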

Compound 3, half-maximal inhibitory concentration: 7300 nM
Compound 3: the middle estimate sits 1.6-fold (0.21 log units) below what was measured; the range from low to high includes it.
By their numbers in this assay, from the lowest: compound 2; then compounds 1 and 3 (each within the scatter of the next).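

Methoxy in place of hydrogen on this saturated chain carbon gives a 2.8-fold higher number from compound 2 to compound 3 (0.44 log units; beyond the scatter) in this assay, a modest weakening that sits beyond the scatter and matches in size what the hydroxy group costs relative to hydrogen. Compound 3 also adds something the first two compounds could not show: the step from hydroxy to methoxy, a 1.0-fold higher number from compound 1 to compound 3 (0.02 log units; within the scatter), lies within the scatter, so putting a methyl on the oxygen leaves no readable mark on the number. Across these three compounds, then, the result tracks whether an oxygen-bearing group sits at this carbon, not whether that oxygen carries a hydrogen or a methyl, and nothing available explains why this is so or bears on this result.

Still open, as far as these compounds go, is whether oxygen matters at all or whether almost any group in place of hydrogen would give the same modest weakening; a methyl, a fluorine or an amine at this carbon would separate those two readings. A longer chain on the oxygen, such as ethoxy or propoxy, would show how far the tolerance seen with methoxy extends.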